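The source may hold more compounds than are shown below. What is called first, only, known or untested is meant among the compounds shown, and "the series" means these compounds.

Compound 1 `CC(C)(C)C1=CC(=O)C=C(NCC(=O)O)C1=O`: 85000 nM
Compound 2 `CC1=CCC[C@H]2[C@](C)(CC3=CC(=O)C=CC3=O)[C@@H](C)CC[C@]12C`: 17100 nM
Compound 3 `CC(C)(C)C1=CC(=O)C=CC1=O`: 15500 nM

All three numbers come from a functional assay on K562 cells (Homo sapiens) for cytotoxicity, read by MTT assay, with a stated time of 72 h; a higher number here means a weaker inhibitor, a lower number a stronger inhibitor. Compound 2 lies within the scatter of compound 3, and beyond the scatter from compound 1, whose number is the highest of the three. Compound 4 `CC1=CCC[C@H]2[C@](C)(CC3=CC(=O)C=C(NCC(=O)O)C3=O)[C@@H](C)CC[C@]12C` derives from compound 2 by (carboxymethyl)amino in place of hydrogen on a double-bonded ring carbon. Among the compounds with values here, one measured step bears on this, the same exchange in the opposite direction on the core of compound 1: a 5.5-fold lower number from compound 1 to compound 3 (0.74 log units; beyond the scatter). Within the data shown here, that step is modest and is the only example. A rise of similar size in this assay, beyond the scatter and toward weaker inhibition, is therefore expected. The estimated value for compound 4 is 85000 nM, with an expected range of 35000 nM to 200000 nM. This estimate means an expected 5.0-fold higher number from compound 2 to compound 4 (0.70 log units; beyond the scatter).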

Compound 4, half-maximal inhibitory concentration: 15600 nM
Compound 4: the middle estimate sits 5.4-fold (0.74 log units) above what was measured; measured number below the stated range.
By their numbers in this assay, from the lowest: compounds 3, 4 and 2 (each within the scatter of the next); then compound 1.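

On the core of compound 2, (carboxymethyl)amino on this double-bonded ring carbon leaves this assay unmoved, with a 1.1-fold lower number from compound 2 to compound 4 (0.04 log units; within the scatter). The weakening seen on the core of compound 1 does not carry over, so this exchange cannot be read as a fixed increment across cores: the same change on two cores in this assay, a 5.5-fold lower number (0.74 log units; beyond the scatter) from compound 1 to compound 3 and a 1.1-fold higher number (0.04 log units; within the scatter) from compound 4 to compound 2, 6.0-fold (0.78 log units) apart, beyond the scatter of two such steps

Still open, from the compounds shown here alone, is whether a plain amine or a longer chain ending in a carboxylic acid at this position would also separate the two cores. With one pair per core, the compounds shown do not tell which part of the cores sets the gap.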